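Replacing the Fluorophenyl Arm with a Carbamoyl Group

The source may hold more compounds than are shown below. What is called first, only, known or untested is meant among the compounds shown, and "the series" means these compounds.

Compound 1, `Cc1n[nH]c(C(=O)O)c1Cc1cccc(-c2cccc(F)c2)c1`: 20%
Compound 2, `Cc1n[nH]c(C(=O)O)c1Cc1cccc(-c2ccccc2F)c1`: 5%

Of the compounds shown here, two sharing one core have been measured so far. In an assay on isolated protein for inhibition of 2-Hydroxyacid oxidase 2 (Homo sapiens), tested at 1 uM (a lower number here means a weaker effect, a higher number a stronger effect of the compound at the concentration tested), compound 1 gives 20%, while compound 2 gives 5%. Compound 2 thus stands lowest of the two, the step being a number 15 percentage points lower from compound 1 to compound 2 (beyond the scatter). Both numbers are small, so neither compound inhibits strongly at this concentration.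

Compound 3, `Cc1n[nH]c(C(=O)O)c1Cc1cccc(C(N)=O)c1`, differs from compound 2 in that (carbamoyl in place of 2-fluorophenyl on an aromatic carbon). Among the measured compounds shown here, the single measured step concerns only where fluorine sits on the outer ring, not the removal of that ring, so it offers no direct guidance on this change. With both measured compounds weak, compound 3 is expected to remain weak as well, and the step of a number 3 percentage points higher from compound 2 to compound 3 (within the scatter) is estimated to lie within the scatter. The estimate for compound 3 in this assay is 8%, with a range from 0% to 25%.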

Compound 3, a percentage reported as inhibition, at one concentration (the size of the read-out at that concentration, not a potency): 8%
Estimate against measurement, compound 3: no gap at the digits printed; low and high end bracket the measured number.
By their numbers in this assay, from the lowest: compounds 2 and 3 (each within the scatter of the next); then compound 1.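

In this assay, replacing the whole outer ring with the much smaller carbamoyl group gives a number 3 percentage points higher from compound 2 to compound 3 (within the scatter). This position therefore tolerates the loss of the 2-fluorophenyl ring with no measurable change, while the comparison with the other fluorinated ring gives a number 12 percentage points lower from compound 1 to compound 3 (beyond the scatter), leaving the 3-fluorophenyl group as the only one of the three that stands apart from the others. No supporting data bear on why these groups read as they do.

The compounds shown leave open how an unsubstituted phenyl, a primary amine or a carboxylic acid at this position would read. Compound 1 gives a modest 20%, and the compounds shown also leave open whether any group placed here can lift inhibition much further.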